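The source may hold more compounds than are shown below. What is called first, only, known or untested is meant among the compounds shown, and "the series" means these compounds.

Working notes on the series. The shared core is carried by compound 1 `CN(C(=O)NCCCOc1ccc2nc(O)ccc2c1)C1CCCCC1`, compound 2 `O=C(NCCCOc1ccc2[nH]c(=O)ccc2c1)N(C1CC1)[C@@H]1CCCC[C@H]1O` and compound 3 `O=C(NCCCOc1ccc2nc(O)ccc2c1)N(C1CCCCCC1)[C@H]1CCCC[C@@H]1O`. In a functional assay on the whole organism for inhibition, with Mus musculus as the target, at a dose of 30 mg/kg by the oral route (a higher number here means more inhibition at the dose given (going by the name of the read-out), a lower number less inhibition), compound 3 gives 69%, the higher of the two single numbers in hand; compound 1 gives 21%, a gap that lies beyond the scatter. Compound 2 gives 100%; 100% (2 entries), two entries rather than one number.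

Compound 4 `O=C(NCCCOc1ccc2nc(O)ccc2c1)N(C1CC1)[C@H]1CCCC[C@@H]1O` is not yet measured. It differs from compound 3 in one place: cyclopropyl in place of cycloheptyl on an amide-type nitrogen. For the measured compounds named here, no measured pair shows this change by itself, so the step is open; compound 2 suggests the series can reach the top of the read-out. An upward step of moderate size is expected, a number 16 percentage points higher from compound 3 to compound 4 (beyond the scatter), though a result within the scatter is also possible. Compound 4 is estimated at 85%, with a range of 60% to 100%.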

Compound 4, a percentage reported as inhibition, in the whole organism at one dose (the size of the read-out at that dose, not a potency): 100%
Estimate against measurement, compound 4: 15 percentage points below; low and high end bracket the measured number.
By their numbers in this assay, from the lowest: compound 1; then compound 3; then compound 4.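

In this assay, for the compounds shown here, cyclopropyl in place of cycloheptyl on the amide-type nitrogen gives a number 31 percentage points higher from compound 3 to compound 4 (beyond the scatter) and is the first measured reading of a change at this position. The read-out therefore responds to the ring carried on this nitrogen, and compound 4 at 100% sits at the top of the scale, where any further gain would not show. No measurement bears on the cause of this step.

Still open, on these data alone, is how an open chain on this nitrogen, such as isopropyl or n-butyl, or a cyclopentyl ring, would read. Compound 4 also leaves open how far its effect holds at a lower dose.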